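Cytotoxicity at the limit: a methyl step on two chains

The source may hold more compounds than are shown below. What is called first, only, known or untested is meant among the compounds shown, and "the series" means these compounds.

Measured compounds in an ADME assay on HEK-293T cells (Homo sapiens) for cytotoxicity, with a stated time of 48 h; a higher number here means that more compound is tolerated, a lower number that less compound is tolerated:
compound 1, `CCc1ncnc(NCc2ccc(C(C)(C)C)cc2)c1Cl`, gives > 10000 nM, which is a limit of the assay and not a number.
compound 2, `CCc1ncnc(NC(C)c2ccc(C(C)(C)C)cc2)c1Cl`, gives > 10000 nM, again a limit.
compound 3, `CCc1ncnc(NC(CC)c2ccc(Oc3ccc(F)cc3)cc2)c1Br`, gives > 10000 nM, also a limit.

Compound 2 arises from compound 1 by methyl in place of hydrogen on a saturated chain carbon bound to an aromatic carbon and a nitrogen on an aromatic ring. The step that the two limits leave unreadable from compound 1 to compound 2 is not readable in size, since both values are limits. Compound 4, `CCCc1ncnc(NC(CC)c2ccc(Oc3ccc(F)cc3)cc2)c1Br`, is not yet measured; it arises from compound 3 by methyl in place of hydrogen on a saturated chain carbon, two bonds along the chain from an aromatic carbon. This is the same kind of change as that from compound 1 to compound 2, though the place differs: in the earlier pair the carbon is bound to an aromatic carbon and a nitrogen on an aromatic ring, in the new pair it lies two bonds along the chain from an aromatic carbon. The difference between the two cores of compound 1 and compound 3 is not broken down here. For compound 4 an unreadable step like the earlier one is expected in this assay, a step that the limit leaves unreadable from compound 3 to compound 4, because of the limit of > 10000 nM in this assay, at which 3 of the 3 values shown sit. Compound 4 is therefore estimated at 20000 nM, between 8000 nM and 60000 nM.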

Compound 4, half-maximal cytotoxic concentration: > 10000 nM
Compound 4 was reported as a limit (the forecaster's own chance of this, stated with the estimate: 85%); the middle value lies beyond the limit too.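

In this assay, compound 3 and compound 4 are both reported only as limits and not as numbers, so no size can be read for the step between them: the limit of > 10000 nM in this assay, at which 4 of the 4 values shown sit.

The compounds shown leave open at what concentration any of them becomes cytotoxic to these cells, and whether either methyl step alters tolerance at all.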